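The compounds below may be only part of what the source reports. "The series", "measured", "known", "first", "only" and "open" are said of these compounds alone.

Compound 1 `COc1ccc(Nc2nc3ccccc3nc2S(=O)(=O)c2ccc(C)cc2)cc1`: > 50000 nM (a limit)
Compound 2 `COc1ccc(Nc2nc3ccccc3nc2S(=O)(=O)c2ccc(OC)cc2)cc1`: 8710 nM

Among the measured compounds shown here, in a functional assay on PC-3 cells (Homo sapiens) for cytotoxicity, read by MTT assay, with a stated time of 72 h (on this read-out lower numbers stand for stronger inhibition and higher numbers for weaker inhibition), compound 2 gives 8710 nM, the only actual number so far. The entry for compound 1 is a limit.

Compound 3 `COc1ccc(S(=O)(=O)c2nc3ccccc3nc2Nc2ccc(F)cc2)cc1` carries fluoro in place of methoxy on an aromatic carbon, (4-methoxyphenyl)amino to (4-fluorophenyl)amino (fluoro in place of methoxy on an aromatic carbon). For the measured compounds named here, the sole measured step, an at least 5.7-fold lower number from compound 1 to compound 2 (0.75 log units; beyond the scatter), is a different change, methoxy in place of methyl, and rests on (the limit of > 50000 nM in this assay, at which 1 of the 2 values shown sits), so it bears only loosely. Compound 3 keeps that methoxy and loses the other. A modest move toward weaker inhibition in this assay is expected, a 1.6-fold higher number from compound 2 to compound 3 (0.21 log units; within the scatter). For compound 3 the estimate is 14000 nM, with an expected range of 4000 nM to 50000 nM.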

Compound 3, half-maximal inhibitory concentration: 2200 nM
For compound 3 the middle estimate is 6.4-fold (0.80 log units) above the measured one; measured number below the stated range.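

In this assay, fluoro in place of methoxy on an aromatic carbon, para to a large group, gives a 4.0-fold lower number from compound 2 to compound 3 (0.60 log units; beyond the scatter). Among the compounds shown here, this is the first step read between two actual numbers, and it shows that the (4-methoxyphenyl)amino position responds to its substituent, which the earlier step, made elsewhere and resting on a limit, could not show. Nothing shown here bears on the cause of this step.

As far as these compounds go, whether the lower number follows from fluoro itself or from the loss of methoxy stays open; chloro or a nitrile at this place would help separate the two. Also open, from the compounds shown here alone, is how an amine or a carboxylic acid would read there.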